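This account rests on a few compounds, and the source may have more. Where it says the series, first, only, none or still open, it means among the compounds named here.

Measured compounds:
Compound 1 `CCC1CCN(c2cc(C(F)(F)F)ccc2CNC(=O)C(C)c2ccc(NS(C)(=O)=O)c(F)c2)CC1` gives 0.7 nM in an assay on CHO cells for antagonist activity at transient receptor potential cation channel subfamily V member 1 (Homo sapiens), read by FLIPR; a lower number here means a stronger inhibitor, a higher number a weaker inhibitor.
Compound 2 `CC(C(=O)NCc1ccc(C(F)(F)F)cc1N1CCC(c2ccc(F)cc2)CC1)c1ccc(NS(C)(=O)=O)c(F)c1` gives 0.9 nM in this assay.
Compound 3 `CC(C(=O)NCc1ccc(C(F)(F)F)cc1N1CCC(Cc2ccccc2)CC1)c1ccc(NS(C)(=O)=O)c(F)c1` gives 1.4 nM in this assay.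

Compound 1 is the reference here: the steps of a 1.3-fold higher number from compound 1 to compound 2 (0.11 log units; within the scatter) and a 2.0-fold higher number from compound 1 to compound 3 (0.30 log units; within the scatter) both lie within the scatter, as does a 1.6-fold higher number from compound 2 to compound 3 (0.19 log units; within the scatter), so the three compounds cannot be separated on these numbers. Compound 4 `CC(C(=O)NCc1ccc(C(F)(F)F)cc1OCc1ccccc1)c1ccc(NS(C)(=O)=O)c(F)c1` differs from compound 1 by benzyloxy in place of 4-ethylpiperidin-1-yl on an aromatic carbon. For the measured compounds named here, no measured step bears directly on this change: every measured step only swaps the group on the saturated ring, while here the saturated ring itself is exchanged for benzyloxy. Those three small steps give no basis to expect a shift beyond the scatter, but the change is larger than any measured one. Compound 4 is therefore expected to give 3 nM, in the range 0.7 nM to 15 nM, a step of a 4.3-fold higher number from compound 1 to compound 4 (0.63 log units; beyond the scatter) estimated from compound 1 with wide uncertainty.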

Compound 4, inhibition constant: 0.9 nM
Beside the measured number, compound 4's estimate is 3.3-fold (0.52 log units) above it; the measured number falls inside the stated range.
By their numbers in this assay, from the lowest: compounds 1, 2, 4 and 3 (each within the scatter of the next).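

In this assay, the group on this aromatic carbon, ortho to a large group and meta to a trifluoromethyl group, can be exchanged entirely: benzyloxy in place of 4-ethylpiperidin-1-yl gives a 1.3-fold higher number from compound 1 to compound 4 (0.11 log units; within the scatter) and so no separable shift. The earlier steps shown here only varied the group on the saturated ring, whereas here the saturated ring and its nitrogen are gone. Nothing measured here offers a reason for this.

Still open, on these data alone, is whether the aromatic ring of benzyloxy matters, which cyclohexylmethoxy would test. Whether a much smaller group, such as methoxy or dimethylamino, would hold the number at this carbon is also unknown.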